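Amide replacement on the chromone oxyacetamide series

The source may hold more compounds than are shown below. What is called first, only, known or untested is meant among the compounds shown, and "the series" means these compounds.

Measured compounds, inhibition of ROCK1 by an assay on isolated protein for inhibition of Rho-associated protein kinase 1 (Homo sapiens), read by scintillation counting, radiometric assay and 33P incorporation, with a stated time of 40 min, in the presence of a further agent that is not named here; on this read-out lower numbers stand for stronger inhibition and higher numbers for weaker inhibition:
- compound 1 `O=C(COc1ccc2c(=O)ccoc2c1)Nc1cccc(NC(=O)c2ccc(F)cc2)c1`: 129 nM
- compound 2 `N#Cc1ccc(C(=O)Nc2cccc(NC(=O)COc3ccc4c(=O)ccoc4c3)c2)cc1`: 123 nM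
- compound 3 `Cc1nc(C(=O)Nc2cccc(NC(=O)COc3ccc4c(=O)ccoc4c3)c2)cs1`: 473 nM

Compound 3 gives the highest number of the three in this assay and is the weakest inhibitor here, since both steps to it lie beyond the scatter. Compound 4 `NCc1ccc(C(=O)Nc2cccc(NC(=O)COc3ccc4c(=O)ccoc4c3)c2)cc1` is not yet measured; it differs from compound 3 by 4-(aminomethyl)phenyl in place of 2-methyl-1,3-thiazol-4-yl on a carbonyl carbon.

Going by the values given here, two measured steps bear on this change, both running in the opposite direction: a 3.7-fold higher number from compound 1 to compound 3 (0.56 log units; beyond the scatter) and a 3.8-fold higher number from compound 2 to compound 3 (0.58 log units; beyond the scatter). Both swaps of a substituted phenyl for the methylthiazolyl raised the number by a modest amount. The substituent on the phenyl made no difference between the two phenyl examples: a 1.0-fold lower number from compound 1 to compound 2 (0.02 log units; within the scatter). Returning from the thiazolyl to a substituted phenyl is therefore expected to lower the number again by a comparable modest step, a 3.2-fold lower number from compound 3 to compound 4 (0.50 log units; beyond the scatter), with the caveat that an aminomethyl group has not been tested on this ring.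

Compound 4 is estimated at 150 nM in this assay, expected between 60 nM and 400 nM.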

Compound 4, half-maximal inhibitory concentration: 532 nM
Compound 4: middle estimate off by 3.5-fold (0.55 log units), on the low side, outside the stated range (above it).
By their numbers in this assay, from the lowest: compounds 2 and 1 (each within the scatter of the next); then compounds 3 and 4 (each within the scatter of the next).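

In this assay, the substituent on the phenyl now matters: fluoro and cyano could not be told apart, but a 4.1-fold higher number from compound 1 to compound 4 (0.62 log units; beyond the scatter) and a 4.3-fold higher number from compound 2 to compound 4 (0.64 log units; beyond the scatter) show that aminomethyl does not fit alongside them. A substituted phenyl on this carbonyl carbon therefore does not by itself separate these compounds from the methylthiazolyl one, as a 1.1-fold higher number from compound 3 to compound 4 (0.05 log units; within the scatter) leaves 4-(aminomethyl)phenyl and 2-methyl-1,3-thiazol-4-yl within the scatter of each other. No evidence is available here that would explain this result.

Still open, on these data alone, is whether the step follows the amine itself or the aminomethyl group as a whole, which a hydroxymethyl, a dimethylaminomethyl or a longer aminoethyl chain on the same phenyl would help settle. As far as these compounds go, a carboxylic acid in that place also remains open.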